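Carbamate side chain variation on the shared core

A few compounds are considered here, and "the series" means these few. Any claim that something is new, unique, unknown or untested is made for them only; others in the source may bear on it.

Compound 1 `CCCCCOC(=O)N1CCN(C(=O)c2nc(Nc3cc(C4CC4)[nH]n3)c3cc(Cl)ccc3n2)C[C@H]1C`, compound 2 `CC(OC(=O)C(C)C)OC(=O)N1CCN(C(=O)c2nc(Nc3cc(C4CC4)[nH]n3)c3cc(Cl)ccc3n2)C[C@H]1C` and compound 3 `C[C@@H]1CN(C(=O)c2nc(Nc3cc(C4CC4)[nH]n3)c3cc(Cl)ccc3n2)CCN1C(=O)OCC(Cl)(Cl)Cl` share one core and differ only in the group on an oxygen next to a carbonyl group. In an assay for inhibition of serine/threonine-protein kinase PAK 4 (Homo sapiens), read by FRET and Z'-LYTE, with a stated time of 60 min, tested at 0.5 uM, in the presence of a further agent that is not named here (a lower number here means a weaker effect, a higher number a stronger effect of the compound at the concentration tested), compound 1 gives -3.8%, compound 2 gives 9.4% and compound 3 gives -1.5%. Compound 2 stands highest of the measured numbers: the step of a number 13.2 percentage points higher from compound 1 to compound 2 (beyond the scatter) lies beyond the scatter, as does a number 10.9 percentage points lower from compound 2 to compound 3 (beyond the scatter), whereas a number 2.3 percentage points higher from compound 1 to compound 3 (within the scatter) stays within it. All three readings sit close to no inhibition at the concentration tested, so even the steps beyond the scatter are modest.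

Compound 4 `CC(OC(=O)N1CCN(C(=O)c2nc(Nc3cc(C4CC4)[nH]n3)c3cc(Cl)ccc3n2)C[C@H]1C)OC(=O)C(C)(C)C` has not yet been measured. Relative to compound 2 the change is methyl in place of hydrogen on a saturated chain carbon bound to a carbonyl carbon and two saturated chain carbons. For the measured compounds named here, none of the measured steps bears directly on this carbon: each of them exchanges the whole group on the oxygen next to a carbonyl group rather than adding one carbon within it. With the measured numbers all near zero and the change confined to one carbon, no step beyond the scatter is expected in this assay; the expected step is a number 2.4 percentage points lower from compound 2 to compound 4 (within the scatter). Compound 4 is therefore estimated at 7%, with a range from -8% to 22%.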

Compound 4, a percentage reported as inhibition, at one concentration (the size of the read-out at that concentration, not a potency): -6.9%
Compound 4: the middle estimate sits 13.9 percentage points above what was measured; measured number inside the range.
By their numbers in this assay, from the lowest: compounds 4, 1 and 3 (each within the scatter of the next); then compound 2.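

In this assay the addition of one methyl on a saturated chain carbon bound to a carbonyl carbon and two saturated chain carbons, which turns isopropyl into tert-butyl, gives a number 16.3 percentage points lower from compound 2 to compound 4 (beyond the scatter) and so shows that this single carbon can shift the reading by a modest amount, something the earlier exchanges of the whole group on the oxygen could not show. Compound 2 now stands alone among the esters and carbamates shown, since 1-(((tert-butyl)carbonyl)oxy)ethyl reads with the simpler groups: the change gives a number 3.1 percentage points lower from compound 1 to compound 4 (within the scatter) against pentyl and a number 5.4 percentage points lower from compound 3 to compound 4 (within the scatter) against 2,2,2-trichloroethyl, so the presence of a 1-(acyloxy)ethyl group alone does not set a compound apart from them. Nothing available here accounts for the step at this carbon.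

The compounds shown leave open whether a straight propyl chain, a cyclopropyl ring or an amine in place of tert-butyl would read with compound 2 or with compound 4. Readings at one concentration, all close to no inhibition, also leave open how far the step reflects any difference in potency.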